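This account rests on a few compounds, and the source may have more. Where it says the series, first, only, none or still open, it means among the compounds named here.

Measured in an ADME assay on Vero cells (Chlorocebus sabaeus) for cytotoxicity, read by trypan blue exclusion, with a stated time of 24 h; on this read-out lower numbers stand for stronger inhibition and higher numbers for weaker inhibition:
- Compound 1 `COc1cc(C[C@@H](C)[C@@H](C)Cc2ccc(OC(C)=O)c(OC)c2)ccc1O`: 112 ug/mL
- Compound 2 `COc1cc(C[C@@H](C)[C@@H](C)Cc2ccc(OC(=O)c3cnccn3)c(OC)c2)ccc1O`: 43.3 ug/mL

Within the data shown here, only two numbers exist so far in this assay. Compound 2 has the lower of them, at 43.3 ug/mL, while compound 1 stands higher, at 112 ug/mL.

The next compound to be measured is compound 3 `COc1cc(C[C@@H](C)[C@@H](C)Cc2ccc(OC(=O)c3ccccn3)c(OC)c2)ccc1O`. It keeps the shared core and changes only the group on a carbonyl carbon: pyridin-2-yl in place of pyrazin-2-yl on a carbonyl carbon. Both groups are six-membered aromatic rings with no net charge.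

Among the measured compounds shown here, one measured step bears on this change: a 2.6-fold lower number from compound 1 to compound 2 (0.41 log units; beyond the scatter). That modest step put pyrazin-2-yl in place of methyl on the same carbonyl carbon, so it replaced a methyl with an aromatic ring. For the measured compounds named here, the new change only trades one aromatic ring for another, and no measured step shows such a trade. With so little evidence, a shift in either direction beyond the scatter is not expected, though this remains uncertain.

The expected step is a 1.1-fold higher number from compound 2 to compound 3 (0.04 log units; within the scatter), within the scatter. For compound 3 the estimated value is 47 ug/mL, with an expected range from 22 ug/mL to 100 ug/mL.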

Compound 3, half-maximal inhibitory concentration: 65 ug/mL
Compound 3: the middle estimate sits 1.4-fold (0.14 log units) below what was measured, within the range that was stated.
By their numbers in this assay, from the lowest: compounds 2, 3 and 1 (each within the scatter of the next, the first and the last beyond it).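

In this assay, putting pyridin-2-yl in place of pyrazin-2-yl on this carbonyl carbon gives a 1.5-fold higher number from compound 2 to compound 3 (0.18 log units; within the scatter), so trading a ring with 2 hetero atoms and 2 hydrogen-bond acceptors for one with 1 hetero atom and 1 hydrogen-bond acceptor makes no clear difference at this position. Measured against the methyl group, pyridin-2-yl gives a 1.7-fold lower number from compound 1 to compound 3 (0.24 log units; within the scatter), which means that, among these compounds, a clear change from methyl is seen only with pyrazin-2-yl and not with both aromatic rings. No supporting measurement is available to explain any of these differences.

The compounds shown leave open whether the small gaps among these three groups would hold up on repeated measurement, and whether the hetero atoms in the ring matter at all, a question that a plain phenyl ring on the same carbonyl carbon would help to answer. They also leave open how an amine or a longer carbon chain at this position would compare with the methyl and the two aromatic rings.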